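Shrinking the amide substituent of compound 2

The compounds below may be only part of what the source reports. "The series", "measured", "known", "first", "only" and "open" are said of these compounds alone.

Compound 1 `CC(NC(=O)C#Cc1ccc(NC(=O)Nc2cc(C(F)(F)F)ccc2Cl)cc1)c1ccccc1`: 3170 nM
Compound 2 `CC(NC(=O)C#Cc1ccc(NC(=O)Nc2ccc(Cl)c(C(F)(F)F)c2)cc1)c1ccccc1`: 4920 nM
Compound 3 `C/C(=C\C(=O)N1CC(C)OC(C)C1)c1ccc(NC(=O)Nc2ccc(Cl)c(C(F)(F)F)c2)cc1`: 26200 nM

In a functional assay on HT-29 cells (Homo sapiens) for inhibition, read by MTT assay, with a stated time of 120 h (a higher number here means a weaker inhibitor, a lower number a stronger inhibitor), compound 2 gives 4920 nM. Going by the values given here, the only measured step, a 1.6-fold higher number from compound 1 to compound 2 (0.19 log units; within the scatter), stays within the scatter and swaps a different group. Compound 3 shows a clearly higher number, 26200 nM.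

Compound 4 `CNC(=O)C#Cc1ccc(NC(=O)Nc2ccc(Cl)c(C(F)(F)F)c2)cc1` carries methyl in place of 1-phenylethyl on an amide-type nitrogen. Among the compounds with values here, no measured step changes this group, so the evidence is thin. Compound 3 also lacks 1-phenylethyl, though it differs in other ways too, and its value of 26200 nM suggests that a higher number, meaning a weaker inhibitor, should be expected. The expected step is a 2.2-fold higher number from compound 2 to compound 4 (0.35 log units; beyond the scatter). The estimate for compound 4 is 11000 nM, with an expected range of 4500 nM to 28000 nM.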

Compound 4, half-maximal inhibitory concentration: 14000 nM
Beside the measured number, compound 4's estimate is 1.3-fold (0.10 log units) below it; low and high end bracket the measured number.
By their numbers in this assay, from the lowest: compounds 1 and 2 (each within the scatter of the next); then compounds 4 and 3 (each within the scatter of the next).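

In this assay, going by these compounds alone, putting methyl in place of 1-phenylethyl on the amide-type nitrogen gives a 2.8-fold higher number from compound 2 to compound 4 (0.45 log units; beyond the scatter) and this is the first measured change at this position. The step lies beyond the scatter but is modest, so the loss of the aromatic ring and all but one carbon of this group leaves a measurable inhibitor. Nothing measured here explains this step. Still open, from the compounds shown here alone, is how a benzyl group, an ethyl group or a chain ending in an amine would behave on this nitrogen.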